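Same Aryl Swap Carried onto a Second Core

The source may report more compounds than this note shows. Statements on the series, on what has been measured and on what is new or still open speak of the compounds shown alone.

Compound 1 `COc1ccc(-n2cc(NC(=O)c3cccc(NS(=O)(=O)c4ccc(Cl)cc4)c3)cn2)cc1` and compound 2 `COc1cccc(-n2cc(NC(=O)c3cccc(NS(=O)(=O)c4ccc(Cl)cc4)c3)cn2)c1` share one core and differ in a single place: 3-methoxyphenyl in place of 4-methoxyphenyl on an aromatic nitrogen. In a functional assay on HeLa cells (Homo sapiens) for inhibition, read by MTT assay, with a stated time of 48 h (on this read-out lower numbers stand for stronger inhibition and higher numbers for weaker inhibition), compound 1 gives 19700 nM and compound 2 gives 25000 nM, so the change produced a 1.3-fold higher number from compound 1 to compound 2 (0.10 log units; within the scatter). Compound 3 `COc1ccc(-n2cc(NC(=O)c3ccc(NS(=O)(=O)c4ccccc4)cc3)cn2)cc1` is built on a different core; the difference between the two cores is not broken down here. In this assay compound 3 gives 47200 nM, the highest of the three numbers. Compound 4 `COc1cccc(-n2cc(NC(=O)c3ccc(NS(=O)(=O)c4ccccc4)cc3)cn2)c1` has not yet been measured; it differs from compound 3 by 3-methoxyphenyl in place of 4-methoxyphenyl on an aromatic nitrogen, the same change that separates compound 1 from compound 2. Because the earlier step was only a 1.3-fold higher number from compound 1 to compound 2 (0.10 log units; within the scatter), the step from compound 3 to compound 4 is expected to be similarly small, a 1.3-fold higher number from compound 3 to compound 4 (0.10 log units; within the scatter). Compound 4 is therefore estimated at 60000 nM in this assay, with a range of 30000 nM to 120000 nM.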

Compound 4, half-maximal inhibitory concentration: 66200 nM
Compound 4: the middle estimate sits 1.1-fold (0.04 log units) below what was measured; low and high end bracket the measured number.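

In this assay, replacing 4-methoxyphenyl with 3-methoxyphenyl on the second core gives a 1.4-fold higher number from compound 3 to compound 4 (0.15 log units; within the scatter). Set beside the earlier step, the result on the second core does not differ from that on the first: the same change on two cores in this assay, a 1.3-fold higher number (0.10 log units; within the scatter) from compound 1 to compound 2 and a 1.4-fold higher number (0.15 log units; within the scatter) from compound 3 to compound 4, 1.1-fold (0.04 log units) apart, within the scatter of two such steps. This shows that the change stayed within the scatter on both cores, but since neither step is distinguishable from repeat measurement, it does not show a real effect that carries over, nor does it extend to any other core.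

The compounds shown leave open how the number would respond if an ethoxy group or an amine took the place of the methoxy group on that phenyl ring. On these data alone, whether the same small step would appear on a third core also remains open.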